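Primary amide restored on the mono-fluoro core

This account rests on a few compounds, and the source may have more. Where it says the series, first, only, none or still open, it means among the compounds named here.

Compound 1 `NC(=O)/C=C1\CCc2c(F)cc(F)cc21` and compound 2 `NC(=O)/C=C1\CCc2cc(F)c(F)cc21` are primary amides; in a functional assay on the whole organism with Mus musculus as the target (a higher number here means that more compound is needed for the effect, a lower number that less compound is needed), compound 1 gives 69 mg/kg and compound 2 gives 64 mg/kg, the two within scatter of each other. Compound 3 `CCCNC(=O)/C=C1\CCc2ccc(F)cc21` carries a propyl group on the amide nitrogen. In this assay compound 3 reaches only a limit of the assay, > 100 mg/kg; it stands at the limit of > 100 mg/kg in this assay, at which 1 of the 3 values shown sits. Compound 4 `NC(=O)/C=C1\CCc2ccc(F)cc21` has not been measured. The change from compound 3 to compound 4 is hydrogen in place of propyl on an amide-type nitrogen. Going by the values given here, no step between measured compounds is available. Since compound 1 gives 69 mg/kg and compound 2 gives 64 mg/kg as numbers, the expected step is an at least 1.4-fold lower number from compound 3 to compound 4 (0.15 log units; that floor lies within the scatter), toward less compound needed. Compound 4 is estimated at 70 mg/kg in this assay, between 40 mg/kg and 130 mg/kg.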

Compound 4, dose for half-maximal effect: 56 mg/kg
Compound 4: middle estimate off by 1.3-fold (0.10 log units), on the high side, within the range that was stated.
By their numbers in this assay, from the lowest: compounds 4, 2 and 1 (each within the scatter of the next). At a limit, above all of these: compound 3.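

In this assay, hydrogen in place of propyl on the amide-type nitrogen can now be read as a step: an at least 1.7-fold lower number from compound 3 to compound 4 (0.25 log units; that floor lies within the scatter). Compound 3 is the one entry at a limit of the assay: the limit of > 100 mg/kg in this assay, at which 1 of the 4 values shown sits. For hydrogen in place of fluoro on an aromatic carbon the steps are a 1.1-fold lower number from compound 2 to compound 4 (0.06 log units; within the scatter) and a 1.2-fold lower number from compound 1 to compound 4 (0.09 log units; within the scatter), so the extra fluoro on the shared core shows no difference beyond the scatter.

Open, on these data alone, is how a methyl or a longer chain on the amide nitrogen would read in this assay. Also open, as far as these compounds go, is what chloro or methoxy in place of the remaining fluoro would give.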